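The source may hold more compounds than are shown below. What is called first, only, known or untested is meant among the compounds shown, and "the series" means these compounds.

Measured so far:
compound 1 `COc1ccc(CNc2nc3cc(N)cc(N)c3nc2-c2ccccc2)cc1OC`, 460 nM in a functional assay on DU-145 cells (Homo sapiens) for inhibition, read by sulforhodamine B assay, with a stated time of 48 h; a lower number here means a stronger inhibitor of growth, a higher number a weaker inhibitor of growth;
compound 2 `COc1cc(CNc2nc3cc(N)cc(N)c3nc2-c2ccccc2)cc(OC)c1OC`, 5250 nM.

Of these two numbers compound 1 holds the lower one. Going by the values given here, the single measured step, an 11-fold higher number from compound 1 to compound 2 (1.06 log units; beyond the scatter), came with methoxy in place of hydrogen on an aromatic carbon.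

Compound 3 `COc1ccc(CNc2nc3cc(N)cc(N)c3nc2-c2ccccc2)cc1` differs from compound 1 by hydrogen in place of methoxy on an aromatic carbon, that is, 3,4-dimethoxyphenyl to 4-methoxyphenyl. Among the compounds with values here, the one measured step bears on this only in reverse: adding a methoxy cost a great deal, so removing one is expected to cost little or nothing beyond the scatter in this assay. Compound 3 is therefore estimated at 400 nM, within 150 nM to 1200 nM, an expected step of a 1.2-fold lower number from compound 1 to compound 3 (0.06 log units; within the scatter).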

Compound 3, concentration for 50% growth inhibition: 21900 nM
For compound 3 the middle estimate is 55-fold (1.74 log units) below the measured one; measured number above the stated range.
By their numbers in this assay, from the lowest: compound 1; then compound 2; then compound 3.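

Taking away this one methoxy, 3,4-dimethoxyphenyl to 4-methoxyphenyl, gives a 48-fold higher number from compound 1 to compound 3 (1.68 log units; beyond the scatter) in this assay, so the group is far from a spare part of the molecule. With an 11-fold higher number from compound 1 to compound 2 (1.06 log units; beyond the scatter) as well, a change in either direction, removing a methoxy or adding one, raises the number, and the 3,4-dimethoxyphenyl group holds the lowest value of these three. Nothing shown here explains why this step is so large. Still open, going by these compounds, is whether a hydroxy group, a fluorine atom or an ethoxy group on this carbon could take the place of the methoxy.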